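The source may hold more compounds than are shown below. What is called first, only, known or untested is meant among the compounds shown, and "the series" means these compounds.

Of the compounds shown here, three sharing one core have been measured in an assay on HEK293 cells for agonist activity at transient receptor potential cation channel subfamily M member 8 (Homo sapiens), read by fluorescence and calcium flux, with a stated time of 15 min (a higher number here means that more compound is needed for the effect, a lower number that less compound is needed), and they differ only in the group carried on the amide-type nitrogen. Compound 1 `Cc1ccc(OCC(=O)N(Cc2cccs2)c2ccccn2)cc1` gives 200 nM. Compound 2 `Cc1ccc(OCC(=O)N(Cc2cccs2)C(C)C)cc1` gives 70 nM, and compound 3 `CCCN(Cc1cccs1)C(=O)COc1ccc(C)cc1` gives 40 nM. Replacing pyridin-2-yl by a small saturated group helps in both cases: a 2.9-fold lower number from compound 1 to compound 2 (0.46 log units; beyond the scatter) and a 5.0-fold lower number from compound 1 to compound 3 (0.70 log units; beyond the scatter). Between the two saturated groups the difference is small, a 1.8-fold lower number from compound 2 to compound 3 (0.24 log units; within the scatter), so compound 3 carries the lowest number shown, but it cannot be separated from compound 2 on these data.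

Compound 4 `Cc1ccc(OCC(=O)N(Cc2cccs2)C2CC2)cc1` is not yet measured. It differs from compound 3 in one place: cyclopropyl in place of propyl on an amide-type nitrogen. The entering group keeps the same count of carbon atoms but closes them into a three-membered non-aromatic ring of carbon only. Among the compounds with values here, the only step that bears on this is the one between two saturated groups of the same size, a 1.8-fold lower number from compound 2 to compound 3 (0.24 log units; within the scatter), which stayed within the scatter. A change of comparable kind is therefore expected to move the number little, if at all, in this assay, with the expectation leaning slightly toward the branched pattern of compound 2, a 1.4-fold higher number from compound 3 to compound 4 (0.14 log units; within the scatter). For compound 4 the estimate in this assay is 55 nM, with a range from 25 nM to 130 nM.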

Compound 4, half-maximal effective concentration: 8 nM
Beside the measured number, compound 4's estimate is 6.9-fold (0.84 log units) above it; measured number below the stated range.
By their numbers in this assay, from the lowest: compound 4; then compounds 3 and 2 (each within the scatter of the next); then compound 1.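

In this assay, within the data shown here, this position proves more sensitive than the earlier compounds suggested: closing the chain into a ring gives a 5.0-fold lower number from compound 3 to compound 4 (0.70 log units; beyond the scatter) and, set against the branched group, an 8.8-fold lower number from compound 2 to compound 4 (0.94 log units; beyond the scatter), whereas propyl and isopropyl could not be told apart. Cyclopropyl and propyl carry the same count of carbon atoms, so that count alone does not set the number here, and the arrangement of those atoms on the amide-type nitrogen matters; the widest step in the series, a 25-fold lower number from compound 1 to compound 4 (1.40 log units; beyond the scatter), also ends at this ring, leaving compound 4 with the lowest number of the four. No evidence is available on what lies behind this effect of the ring.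

On these data alone, whether the gain is specific to a three-membered ring remains open, and cyclobutyl, a larger ring of carbon only, or a cyclopropylmethyl group, with its ring set one carbon away from the nitrogen, would help to settle that. As far as these compounds go, the rest of the shared core is the same in all four compounds, so it is also open whether the advantage of cyclopropyl would persist if the thiophene-bearing or methylphenoxy parts were changed.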